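A few compounds are considered here, and "the series" means these few. Any claim that something is new, unique, unknown or untested is made for them only; others in the source may bear on it.

Measured compounds:
Compound 1 `O=S(=O)(Nc1ccc2oc(-c3ccccc3)nc2c1)c1cccc(O)c1` in an assay on cells for inhibition of HSP60/HSP10 (Homo sapiens), with a stated time of 60 min (on this read-out higher numbers stand for weaker inhibition and lower numbers for stronger inhibition), gives 76000 nM.
Compound 2 `CCc1ccc(S(=O)(=O)Nc2ccc3oc(-c4ccccc4)nc3c2)cc1` in this assay gives > 100000 nM, which is a limit of the assay and not a number.

Compound 2 thus stands at the limit of > 100000 nM in this assay, at which 1 of the 2 values shown sits, so only a limit or a range is known for it. Among the compounds with values here, the one measured step that bears on the change considered here is an at least 1.3-fold higher number from compound 1 to compound 2 (0.11 log units; that floor lies within the scatter), in which 4-ethylphenyl took the place of 3-hydroxyphenyl on the sulfonyl sulfur; its floor lies within the scatter. Compound 3 `O=S(=O)(Nc1ccc2oc(-c3ccccc3)nc2c1)c1ccccc1O` differs from compound 2 by 2-hydroxyphenyl in place of 4-ethylphenyl on a sulfonyl sulfur. A hydroxyphenyl group thereby returns to the sulfonyl sulfur, as in compound 1 with its 76000 nM. A move back toward that neighbourhood seems the most that the data support, though the assay may again report only a limit for compound 3. Compound 3 is therefore expected to give 80000 nM, within 30000 nM to 200000 nM. The step this estimate means is an at least 1.2-fold lower number from compound 2 to compound 3 (0.09 log units; that floor lies within the scatter).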

Compound 3, half-maximal inhibitory concentration: 85000 nM
Estimate against measurement, compound 3: 1.1-fold (0.03 log units) below, and the stated range covers the measured number.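

In this assay, 2-hydroxyphenyl in place of 3-hydroxyphenyl on the sulfonyl sulfur gives a 1.1-fold higher number from compound 1 to compound 3 (0.05 log units; within the scatter), so these two hydroxyphenyl groups cannot be told apart on this read-out. Against 4-ethylphenyl the change gives an at least 1.1-fold lower number from compound 2 to compound 3 (0.07 log units; that floor lies within the scatter), and this floor alone does not separate the two groups. Compound 2 is known only through a limit of the assay, not a number: the limit of > 100000 nM in this assay, at which 1 of the 3 values shown sits.

The compounds shown leave open how far compound 2 truly lies from the two hydroxyphenyl compounds. They also leave open whether another group on the sulfonyl sulfur, such as an aminophenyl or a carboxyphenyl group, would give a number clearly lower than those of compound 1 and compound 3.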